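The source may report more compounds than this note shows. Statements on the series, on what has been measured and on what is new or still open speak of the compounds shown alone.

Measured in a functional assay on HeLa cells (Homo sapiens) for cytotoxicity, read by MTT assay, with a stated time of 72 h; on this read-out lower numbers stand for stronger inhibition and higher numbers for weaker inhibition:
- compound 1 `COc1ccc(Nc2ccc3ccccc3n2)cc1`: 51000 nM
- compound 2 `COc1ccc(Nc2cccnc2)cc1`: 145000 nM
- compound 3 `Fc1ccc(Nc2ccc3ccccc3n2)cc1`: 33000 nM

Compound 1 holds the second highest of the three numbers. Compound 4 `COc1ccc(Nc2nc3ccccc3cc2-c2ccc(C)cc2)cc1` is compound 1 with 4-methylphenyl in place of hydrogen on an aromatic carbon, (4-methylphenyl in place of hydrogen on an aromatic carbon). Within the data shown here, the only measured step, a 1.5-fold lower number from compound 1 to compound 3 (0.19 log units; within the scatter), swaps fluoro for methoxy at a different place and stays within the scatter, so it says little here. Among the measured compounds shown here, no measured compound carries a group at this carbon. The smaller compound 2 reads higher at 145000 nM, which is only a weak hint that a larger compound may read lower. A modest fall is therefore expected, estimated as a 2.3-fold lower number from compound 1 to compound 4 (0.37 log units; beyond the scatter). The estimated value for compound 4 is 22000 nM, within an expected range from 5000 nM to 80000 nM.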

Compound 4, half-maximal inhibitory concentration: 102000 nM
Beside the measured number, compound 4's estimate is 4.6-fold (0.67 log units) below it; the measured number lies above the stated range.
By their numbers in this assay, from the lowest: compounds 3, 1, 4 and 2 (each within the scatter of the next, the first and the last beyond it).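

Among these compounds, measured in this assay the change from hydrogen to 4-methylphenyl on this aromatic carbon gives a 2.0-fold higher number from compound 1 to compound 4 (0.30 log units; within the scatter) and is the first reading for any group at this carbon. So a full extra aromatic ring here leaves the number within the usual scatter of compound 1, and the position accepts this large group without a clear shift in either direction. No measurement at hand offers a reason for this result. Still open, from the compounds shown here alone, is how an amine or a carboxylic acid would read at this carbon. Going by these compounds, it is also open whether a small group such as chloro would read any differently from 4-methylphenyl.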